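Can a methoxy group match the methyl of compound 3?

A few compounds are considered here, and "the series" means these few. Any claim that something is new, unique, unknown or untested is made for them only; others in the source may bear on it.

compound 1 `COc1ccc(C(=O)c2sc(Nc3ccccc3)nc2N)cc1OC` gives 5500 nM
compound 2 `COc1cc(C(=O)c2sc(Nc3ccc(F)cc3)nc2N)cc(OC)c1OC` gives 280 nM
compound 3 `COc1cc(C(=O)c2sc(Nc3ccc(C)cc3)nc2N)cc(OC)c1OC` gives 21 nM

All three numbers come from a functional assay on MOLT-4 cells (Homo sapiens) for antiproliferative activity, read by cell counting, with a stated time of 2 days (a higher number here means a weaker inhibitor, a lower number a stronger inhibitor), so lower is better. Compound 3, at 21 nM in this test, has the lowest number of the three, and its gaps to compound 2 and compound 1 both lie beyond the scatter.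

The next compound is compound 4 `COc1ccc(Nc2nc(N)c(C(=O)c3cc(OC)c(OC)c(OC)c3)s2)cc1`, which has not been measured yet. The change from compound 3 is methoxy in place of methyl on an aromatic carbon in one place: methoxy in place of methyl on an aromatic carbon, para to a large group.

Among the compounds with values here, only one measured step touches this place. The step of a 13-fold lower number from compound 2 to compound 3 (1.12 log units; beyond the scatter) is large and came with methyl in place of fluoro on an aromatic carbon. It shows that a single swap here can move the number a long way, but it does not show what methoxy will do. Compound 1 differs from the others in more than one place, so it offers no clean comparison.

With so little to go on, only a small rise in the number is expected, and the estimated step is a 1.7-fold higher number from compound 3 to compound 4 (0.22 log units; within the scatter) in this assay. The range is kept wide in view of the size of that one measured step. The estimate for compound 4 is 35 nM, with an expected range from 9 nM to 150 nM.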

Compound 4, half-maximal inhibitory concentration: 480 nM
Compound 4: the middle estimate sits 14-fold (1.14 log units) below what was measured; the whole stated range lies below it.
By their numbers in this assay, from the lowest: compound 3; then compounds 2 and 4 (each within the scatter of the next); then compound 1.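

The swap of methyl for methoxy on this aromatic carbon, para to a large group, is far from neutral in this assay: a 23-fold higher number from compound 3 to compound 4 (1.36 log units; beyond the scatter) is a large loss, about as large as the gain seen when methyl replaced fluoro. Methoxy and fluoro, by contrast, give results that cannot be told apart, since a 1.7-fold higher number from compound 2 to compound 4 (0.23 log units; within the scatter) stays within the scatter. Among these three groups, then, only methyl gives a low number, so the earlier jump from fluoro to methyl was not a sign that fluoro alone was poor, and the larger group containing oxygen does not carry over the benefit of methyl.

These compounds leave open whether the advantage belongs to methyl alone, or whether a chloro group, an ethyl group or an amine at the same place would stay close to compound 3. They also leave open how a plain hydrogen would compare on this same core, since compound 1 differs in more than one place. No measurement shown here bears on why this swap changes the number so strongly.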